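The source may report more compounds than this note shows. Statements on the series, on what has been measured and on what is new or still open speak of the compounds shown alone.

In an ADME assay on Vero cells (Chlorocebus sabaeus) for cytotoxicity, read by MTT assay, with a stated time of 72 h (a higher number here means that more compound is tolerated, a lower number that less compound is tolerated), compound 1 `O[C@@H]1Cc2cc(Cl)ccc2N[C@H](c2ccccc2)C1` gives 191000 nM. For compound 2 `O[C@@H]1Cc2cc(F)ccc2N[C@H](c2ccccc2)C1` the this assay reports only a limit, > 300000 nM. The step of an at least 1.5-fold higher number from compound 1 to compound 2 (0.19 log units; that floor lies within the scatter) can therefore be sized only from its floor. Compound 3 `COc1cccc([C@@H]2C[C@H](O)Cc3ccccc3N2)c1` likewise returns only a limit, > 300000 nM. Compound 3 thus stands at the limit of > 300000 nM in this assay, at which 2 of the 3 values shown sit. Compound 4 `O[C@@H]1Cc2ccccc2N[C@H](c2cccc(Cl)c2)C1` differs from compound 3 by chloro in place of methoxy on an aromatic carbon. For the measured compounds named here, no measured step exchanges methoxy for chloro. Going by the values given here, the only measured step, an at least 1.5-fold higher number from compound 1 to compound 2 (0.19 log units; that floor lies within the scatter), concerns a halogen swap and is of uncertain size. Compound 1, which also carries a chloro, gives 191000 nM. Compound 4 is therefore expected to show a step of an at least 1.5-fold lower number from compound 3 to compound 4 (0.17 log units; that floor lies within the scatter) that may remain within the scatter, with an estimated 200000 nM between 80000 nM and 300000 nM.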

Compound 4, half-maximal cytotoxic concentration: 295000 nM
For compound 4 the middle estimate is 1.5-fold (0.17 log units) below the measured one, within the range that was stated.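

Chloro in place of methoxy on an aromatic carbon, meta to a large group, gives in this assay an at least 1.0-fold lower number from compound 3 to compound 4 (0.00 log units; that floor lies within the scatter), so this exchange shows no step beyond the scatter. Unlike compound 3, compound 4 gives a measured number at this position, 295000 nM. The size of the step remains only a floor, since the value of compound 3 is a limit: the limit of > 300000 nM in this assay, at which 2 of the 4 values shown sit.

The compounds shown leave open how an amine or a carboxylic acid at this position would read in this assay. They also leave open whether the true gap between methoxy and chloro here is larger than that floor.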